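The compounds below may be only part of what the source reports. "The series", "measured", "known", "first", "only" and "open" are said of these compounds alone.

Measured compounds:
- Compound 1 `COc1ccc(-n2cc(COc3c(/C=C\C(=O)O)ccc(OC)c3CC=C(C)C)nn2)cc1`: "not determined" (no result reported)
- Compound 2 `COc1ccc(/C=C\C(=O)O)c(OCc2cn(-c3ccccc3)nn2)c1CC=C(C)C`: 21200 nM
- Compound 3 `COc1ccccc1-n1cc(COc2c(/C=C\C(=O)O)ccc(OC)c2CC=C(C)C)nn1`: 32600 nM

The three compounds share one core, a cinnamic acid carrying a prenyl chain and a methoxy group, linked through a triazole to a phenyl ring that differs only in its substituent. In a functional assay on A-431 cells (Homo sapiens) for cytotoxicity, read by MTT assay, with a stated time of 24 h (a higher number here means a weaker inhibitor, a lower number a stronger inhibitor), compound 2 gives 21200 nM and compound 3 gives 32600 nM. Going by the values given here, the only step between measured compounds, a 1.5-fold higher number from compound 2 to compound 3 (0.19 log units; within the scatter), shows that a methoxy in place of hydrogen on the phenyl ring leaves the read-out within the scatter. Compound 1 stands nowhere on these numbers: no result was reported for it, so its place can only be inferred from the fact that it carries the same core as compounds 2 and 3 and differs from them only on the phenyl ring.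

The unmeasured compound 4 `COc1ccc(/C=C\C(=O)O)c(OCc2cn(-c3ccc(NC(C)=O)cc3)nn2)c1CC=C(C)C` is reached from compound 1 by acetamido in place of methoxy on an aromatic carbon. Among the compounds with values here, no measured step addresses an acetamido group, so the expectation rests on the observation that the one phenyl-ring change recorded here did not move the read-out beyond the scatter. Compound 4 is therefore estimated to sit near compounds 2 and 3, at 26000 nM, with a range from 8000 nM to 85000 nM.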

Compound 4, half-maximal inhibitory concentration: 23400 nM
For compound 4 the middle estimate is 1.1-fold (0.05 log units) above the measured one; the measured number falls inside the stated range.
By their numbers in this assay, from the lowest: compounds 2, 4 and 3 (each within the scatter of the next).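

In this assay, putting acetamido on the phenyl ring, para to a large group, brings in a hydrogen-bond donor and a longer substituent, yet the read-out stays level with the unsubstituted phenyl of compound 2 (a 1.1-fold higher number from compound 2 to compound 4 (0.04 log units; within the scatter)). Against the 2-methoxyphenyl of compound 3, the 4-acetamidophenyl of compound 4 also stays level (a 1.4-fold lower number from compound 3 to compound 4 (0.14 log units; within the scatter)), so neither a different group nor a different place on this ring separates these three compounds. Nothing available explains why the read-out holds steady across these changes.

The direct step from 4-methoxyphenyl to 4-acetamidophenyl cannot be read, since compound 1 has no reported number. Still open, on these data alone, is whether a free amine or a carboxylic acid in this same place, or a longer chain ending in either, would move the read-out beyond the scatter, or whether this ring simply has little influence on cytotoxicity in these cells.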